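The source may hold more compounds than are shown below. What is called first, only, known or untested is meant among the compounds shown, and "the series" means these compounds.

Among the compounds with values here, compound 2, `C[C@H]1CC[C@@H]2[C@@H](OC(=O)[C@]23CC(c2ccc(C#N)cc2)N(c2ccccc2)O3)[C@]2(C)C(=O)C=C[C@@]12O`, stands highest of the two numbers measured so far in a physicochemical assay for lipophilicity; on this read-out higher numbers stand for higher lipophilicity and lower numbers for lower lipophilicity: compound 2 gives 2.94, while compound 1, `C[C@H]1CC[C@@H]2[C@@H](OC(=O)[C@]23CC(c2ccccc2)=NO3)[C@]2(C)C(=O)C=C[C@@]12O`, gives 1.41, a gap beyond the usual scatter. Compound 3, `C[C@H]1CC[C@@H]2[C@@H](OC(=O)[C@]23CC(c2ccccc2Cl)N(c2ccccc2)O3)[C@]2(C)C(=O)C=C[C@@]12O`, differs from compound 2 in one place: 2-chlorophenyl in place of 4-cyanophenyl on a saturated ring carbon. Within the data shown here, no step between two measured compounds matches this change, so the expectation rests on the change alone. The step of a number 0.96 log units higher from compound 2 to compound 3 (beyond the scatter) is expected to be an increase, beyond the scatter. Compound 3 is therefore estimated at 3.9, with a likely range from 3.3 to 4.6.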

Compound 3, partition coefficient: 3.87
For compound 3 the middle estimate is 0.03 log units above the measured one; low and high end bracket the measured number.
By their numbers in this assay, from the lowest: compound 1; then compound 2; then compound 3.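

On this saturated ring carbon, the choice of aryl group clearly matters in this assay: 2-chlorophenyl in place of 4-cyanophenyl gives a number 0.93 log units higher from compound 2 to compound 3 (beyond the scatter). Nothing available accounts for the size of this step.

The swap alters both the substituent and where it sits on the aromatic ring, so the compounds shown cannot separate those two changes. Also open, on these data alone, is how 4-chlorophenyl, or a phenyl group carrying an amine or a carboxylic acid, would read at this carbon.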